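The source may report more compounds than this note shows. Statements on the series, on what has been measured and on what is new or still open speak of the compounds shown alone.

Measured compounds:
compound 1, `Oc1cc(C(F)(F)F)ccc1-c1nc(-c2ccccc2O)n(-c2ccc(Cl)cc2)n1`, giving 96.1%
compound 2, `Oc1cc(C(F)(F)F)ccc1-c1nc(-c2ccccc2O)n(-c2ccc(OC(F)(F)F)cc2)n1`, giving 92.5%
compound 3, `Oc1cc(C(F)(F)F)ccc1-c1nc(-c2ccccc2O)n(-c2ccccc2F)n1`, giving 100%

All three were tested in a functional assay on PC-12 cells (Rattus norvegicus) for cytotoxicity, read by MTT assay, with stated times of 2 h and 24 h, tested at 10 uM; a lower number here means a weaker effect, a higher number a stronger effect of the compound at the concentration tested. Compound 3 has the highest of the three numbers, but its lead is small: compound 1 sits a number 3.9 percentage points higher from compound 1 to compound 3 (within the scatter), and compound 2 sits a number 7.5 percentage points higher from compound 2 to compound 3 (within the scatter), so the three cannot be ordered against one another. The step between compound 1 and compound 2, a trifluoromethoxy in place of a chloro on an aromatic carbon, reads a number 3.6 percentage points lower from compound 1 to compound 2 (within the scatter).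

Compound 4, `Oc1cc(C(F)(F)F)ccc1-c1nc(-c2ccccc2O)n(-c2ccccc2Cl)n1`, has not yet been measured. It differs from compound 3 by chloro in place of fluoro on an aromatic carbon. The measured steps that bear on this are the exchanges of groups on the aryl attached to the aromatic nitrogen: a number 3.6 percentage points lower from compound 1 to compound 2 (within the scatter), a number 3.9 percentage points higher from compound 1 to compound 3 (within the scatter) and a number 7.5 percentage points higher from compound 2 to compound 3 (within the scatter). None of them moved the read-out beyond the scatter, and all three compounds sit close to the top of the scale in this assay. A step of no size beyond the scatter is therefore expected, estimated as a number 4 percentage points lower from compound 3 to compound 4 (within the scatter). Compound 4 is expected to give 96%, within a range from 86% to 100%.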

Compound 4, a percentage reported as activity, at one concentration (the size of the read-out at that concentration, not a potency): 102%
Compound 4: the middle estimate sits 6 percentage points below what was measured, outside the stated range (above it).
By their numbers in this assay, from the lowest: compounds 2, 1, 3 and 4 (each within the scatter of the next).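

Chloro in place of fluoro on an aromatic carbon, ortho to a large group, is the first exchange here that alters only the halogen at one place on the aryl, and in this assay it reads a number 2 percentage points higher from compound 3 to compound 4 (within the scatter), so this place accepts either halogen with no change that can be told from the scatter. Among the compounds shown here, the pair with 2-chlorophenyl in place of 4-chlorophenyl is the first to keep the halogen the same while its place on the aryl differs, and it reads a number 5.9 percentage points higher from compound 1 to compound 4 (within the scatter), while the exchange for 4-(trifluoromethoxy)phenyl, the widest gap among the four, reads a number 9.5 percentage points higher from compound 2 to compound 4 (within the scatter), so neither the place of the chloro nor the wider exchange separates these compounds. Nothing available explains why the four read as they do.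

All four carry a halogen or trifluoromethoxy on this aryl and read close to the top of the scale at a single concentration, so they cannot be ranked against one another. As far as these compounds go, whether an amine, a carboxylic acid or a longer alkyl chain on this aryl would bring the read-out down stays open, as does the part played by the two hydroxy groups of the shared core.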